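This account rests on a few compounds, and the source may have more. Where it says the series, first, only, none or still open, it means among the compounds named here.

Measured so far in a functional assay (Pituitary gland cell) with Rattus norvegicus as the target; a lower number here means that less compound is needed, a higher number that more compound is needed for the effect: compound 2 `CC(C)(N)CC(=O)N[C@@H]1CCc2ccccc2N(Cc2ccc(-c3ccccc3C(=O)NCc3ccc(O)cc3)cc2)C1=O` gives 0.3 uM; compound 1 `CC(C)(N)CC(=O)N[C@@H]1CCc2ccccc2N(Cc2ccc(-c3ccccc3C(=O)NCc3ccccc3)cc2)C1=O` gives 0.9 uM.

Compound 2 stands at the lowest of the two numbers. Among the compounds with values here, the one step with a bearing is a 3.0-fold lower number from compound 1 to compound 2 (0.48 log units; beyond the scatter), which kept the 4-hydroxyphenyl ring and only added its hydroxy.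

Compound 3 `CC(C)(N)CC(=O)N[C@@H]1CCc2ccccc2N(Cc2ccc(-c3ccccc3C(=O)NCCCO)cc2)C1=O` differs from compound 2 by 2-hydroxyethyl in place of 4-hydroxyphenyl on a saturated chain carbon bound to an amide-type nitrogen. The hydroxy stays, so the gain shown by compound 1 against compound 2 is not plainly reversed; no measured step tells what the ring itself contributes. Compound 3 is expected to need somewhat more compound, a 3.3-fold higher number from compound 2 to compound 3 (0.52 log units; beyond the scatter), estimate 1 uM (range 0.3 uM to 4 uM).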

Compound 3, concentration for half-maximal effect: 0.4 uM
Beside the measured number, compound 3's estimate is 2.5-fold (0.40 log units) above it, and the stated range covers the measured number.
By their numbers in this assay, from the lowest: compounds 2 and 3 (each within the scatter of the next); then compound 1.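

In this assay, 2-hydroxyethyl in place of 4-hydroxyphenyl gives a 1.3-fold higher number from compound 2 to compound 3 (0.12 log units; within the scatter) at this position, so the aromatic ring can leave without a change beyond the scatter. 2-Hydroxyethyl in place of phenyl gives a 2.3-fold lower number from compound 1 to compound 3 (0.35 log units; beyond the scatter) here, so both hydroxy-bearing compounds sit apart from compound 1, whether the hydroxy stands on a ring or on a chain. Nothing measured accounts for these numbers.

Still open, as far as these compounds go, is whether the hydroxy is what matters on the chain, as a plain propyl group would show. An amine or a carboxylic acid at the chain end, or a longer chain, also remains to be read in this assay.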